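A few compounds are considered here, and "the series" means these few. Any claim that something is new, unique, unknown or untested is made for them only; others in the source may bear on it.

Working notes on the series. Of the compounds shown here, three have numbers so far in a functional assay (muscle tissue) with Cavia porcellus as the target; on this read-out higher numbers stand for an effect only at larger amounts of compound and lower numbers for an effect already at smaller amounts. Compound 1 `COC(=O)C1=C(C)N=C(C)/C(=C(\O)OC)C1c1c(F)c(F)c(F)c(F)c1F` gives 4.37 nM. Compound 2 `COC(=O)C1=C(C)N=C(C)/C(=C(\O)OC)C1c1ccccc1I` gives 46.8 nM. Compound 3 `COC(=O)C1=C(C)N=C(C)/C(=C(\O)OC)C1c1ccc(I)cc1` gives 22900 nM, the highest number of the three; compound 2 is its nearest neighbour and compound 1 its furthest. For the measured compounds named here, the one measured step bearing on the matter is a 490-fold higher number from compound 2 to compound 3 (2.69 log units; beyond the scatter), a large move upward in number when the iodine sits on the 4-position of the phenyl instead of the 2-position.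

Compound 4 `COC(=O)C1=C(C)N=C(C)/C(=C(\O)OC)C1c1c(Cl)cccc1Cl` has not yet been measured. Its change from compound 3 is 2,6-dichlorophenyl in place of 4-iodophenyl on a saturated ring carbon. This puts substituents back onto the 2- and 6-positions of the phenyl, as in compound 2 and compound 1, both of which have low numbers on this assay. A large step downward in number is therefore expected, of roughly the size seen between compound 2 and compound 3 but reversed. The estimated step for this change is a 1900-fold lower number from compound 3 to compound 4 (3.28 log units; beyond the scatter). Compound 4 is estimated at 12 nM in this assay, with a likely range from 2.5 nM to 70 nM.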

Compound 4, half-maximal effective concentration: 1.91 nM
Estimate against measurement, compound 4: 6.3-fold (0.80 log units) above; measured number outside the range, below it.
By their numbers in this assay, from the lowest: compound 4; then compound 1; then compound 2; then compound 3.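

On this saturated ring carbon in this assay, the change to 2,6-dichlorophenyl gives a 12000-fold lower number from compound 3 to compound 4 (4.08 log units; beyond the scatter), so a low number here does not depend on iodine or on fluorine. Among the compounds with halogen on the phenyl, the position at the 2-iodophenyl level is not a floor: 2,6-dichlorophenyl in place of 2-iodophenyl gives a 25-fold lower number from compound 2 to compound 4 (1.39 log units; beyond the scatter), a step beyond the scatter between two groups that both carry halogen there. Nothing available bears on why these steps have this size.

The compounds shown do not separate the second chlorine from the change of halogen, so it stays open whether 2-chlorophenyl would sit nearer compound 2 or compound 4. Also open, from the compounds shown here alone, is whether halogen is needed at all on this phenyl, for instance with a methoxy group or an amine in its place.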